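The source may hold more compounds than are shown below. What is called first, only, known or untested is meant among the compounds shown, and "the series" means these compounds.

Working notes on the series. Compound 1 `Cc1ccnc(NS(=O)(=O)c2ccc3nc(-c4ccccc4)c(-c4ccccc4)nc3c2)c1` gives 100% in an ADME assay on the whole organism for pharmacokinetics, with Homo sapiens as the target; on this read-out lower numbers stand for lower oral bioavailability and higher numbers for higher oral bioavailability; compound 3 `O=C(NS(=O)(=O)c1ccc2nc(-c3ccccc3)c(-c3ccccc3)nc2c1)c1ccccc1` gives 100% in this assay, and compound 2 `O=[N+]([O-])c1ccc(NS(=O)(=O)c2ccc3nc(-c4ccccc4)c(-c4ccccc4)nc3c2)cc1` gives 87.6% in this assay. Compound 1 thus stands level with compound 3 at the digits shown, the two together at the top of the three numbers; no change at the digits printed from compound 1 to compound 3 (within the scatter), while a number 12.4 percentage points lower from compound 1 to compound 2 (beyond the scatter) and, the other way round, a number 12.4 percentage points higher from compound 2 to compound 3 (beyond the scatter).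

Compound 4 `O=S(=O)(Nc1ccc(Cl)cc1)c1ccc2nc(-c3ccccc3)c(-c3ccccc3)nc2c1` differs from compound 1 in one place: 4-chlorophenyl in place of 4-methylpyridin-2-yl on a sulfonamide nitrogen. Among the compounds with values here, two measured steps bear on this. The step to compound 2 also puts a six-membered carbon-only aromatic ring on the sulfonamide nitrogen in place of the 4-methylpyridin-2-yl group and read a number 12.4 percentage points lower from compound 1 to compound 2 (beyond the scatter); the step to compound 3 read no change at the digits printed from compound 1 to compound 3 (within the scatter). On that basis a small drop, at most a modest one, or no change beyond the scatter is expected in this assay, giving an estimated a number 10 percentage points lower from compound 1 to compound 4 (within the scatter). Compound 4 is therefore expected at about 90%, within roughly 70% to 100%.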

Compound 4, oral bioavailability: 100%
Compound 4: the middle estimate sits 10 percentage points below what was measured, and the stated range covers the measured number.
By their numbers in this assay, from the lowest: compound 2; then compounds 1, 3 and 4 (each within the scatter of the next).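

Working notes, continued. In this assay a carbon-only aromatic ring on the sulfonamide nitrogen does not in itself go with a lower number: 4-chlorophenyl in place of 4-methylpyridin-2-yl gives no change at the digits printed from compound 1 to compound 4 (within the scatter) on this read-out, and 4-chlorophenyl in place of benzoyl gives no change at the digits printed from compound 3 to compound 4 (within the scatter) on it as well. The lower number therefore belongs to the 4-nitrophenyl compound alone among the four, not to the carbon-only ring as such, with chloro in place of nitro on an aromatic carbon giving a number 12.4 percentage points higher from compound 2 to compound 4 (beyond the scatter) in the same read-out. Nothing measured here explains the difference between chloro and nitro.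

Compounds 1, 3 and 4 stand level, so the shown groups do not separate them. Open, from the compounds shown here alone, is how an amine or a carboxylic acid on the phenyl ring, or a simple alkyl chain on the sulfonamide nitrogen, would read.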